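Trimming a sec-butyl side chain to isopropyl on a cyclohexyl hydantoin

A few compounds are considered here, and "the series" means these few. Any claim that something is new, unique, unknown or untested is made for them only; others in the source may bear on it.

Measured so far:
compound 1, `CCC(C)C1NC(=O)N(C2CCCCC2)C1=O`, 69700 nM
compound 2, `CCC(C)C1NC(=O)N(C2CCCC2)C1=O`, > 100000 nM
compound 3, `CC(C)C1NC(=O)N(C2CCCC2)C1=O`, 98000 nM

In a functional assay on HEp-2 cells (Homo sapiens) for inhibition (a lower number here means a stronger inhibitor, a higher number a weaker inhibitor), compound 1 gives 69700 nM. For compound 2 the value > 100000 nM is a limit of the assay and not a number (the limit of > 100000 nM in this assay, at which 1 of the 3 values shown sits). Compound 3 gives 98000 nM. Compound 3 arises from compound 2 by the change (hydrogen in place of methyl on a saturated chain carbon, two bonds along the chain from a saturated ring carbon), and that step is an at least 1.0-fold lower number from compound 2 to compound 3 (0.00 log units; that floor lies within the scatter). The difference between the core of compound 1 and the core of compound 2 is not broken down here. Compound 4, `CC(C)C1NC(=O)N(C2CCCCC2)C1=O`, is the same kind of change made on compound 1: hydrogen in place of methyl on a saturated chain carbon, two bonds along the chain from a saturated ring carbon. Since the same change from compound 2 to compound 3 stayed within the scatter, a flat step a 1.1-fold higher number from compound 1 to compound 4 (0.06 log units; within the scatter) is expected, and compound 4 is estimated at 80000 nM, between 35000 nM and 200000 nM.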

Compound 4, half-maximal inhibitory concentration: 100000 nM
The estimate for compound 4 lay 1.3-fold (0.10 log units) below the measured number; measured number inside the range.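

In this assay, trimming sec-butyl to isopropyl on the core of compound 1 gives a 1.4-fold higher number from compound 1 to compound 4 (0.16 log units; within the scatter), so on this core the change cannot be told apart from the scatter. Compound 2 gives > 100000 nM, which is a limit of the assay and not a number. The change may therefore carry over from one core to the other without a clear step, but that is not shown, and neither is a real difference between the two steps: the same change on two cores in this assay, an at least 1.0-fold lower number (0.00 log units; that floor lies within the scatter) from compound 2 to compound 3 and a 1.4-fold higher number (0.16 log units; within the scatter) from compound 1 to compound 4; the limit leaves it open whether they differ

The compounds shown leave open whether a different group in place of the sec-butyl chain, such as a longer chain, an amine or a carboxylic acid, would shift the number beyond the scatter on either core.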